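A few compounds are considered here, and "the series" means these few. Any claim that something is new, unique, unknown or untested is made for them only; others in the source may bear on it.

Measured compounds:
- compound 1, `Cc1cn(C2CC(N=[N+]=[N-])C(COC(=O)NCCCO)O2)c(=O)[nH]c1=O`: in a functional assay on MT4 cells (Homo sapiens) for cytotoxicity (a lower number here means that less compound is tolerated, a higher number that more compound is tolerated), compound 1 gives > 50000 nM.
- compound 2, `CCCCOC(=O)OCC1OC(n2cc(C)c(=O)[nH]c2=O)CC1N=[N+]=[N-]`: in this assay compound 2 gives > 50000 nM.

The value for compound 1 is a limit of the assay, not a number. The value for compound 2 is likewise a limit of the assay. Both compounds share the same core and differ only where a butoxy replaces a (3-hydroxypropyl)amino on a carbonyl carbon; the step between them is a step that the two limits leave unreadable from compound 1 to compound 2, so the two limits show no difference that can be read. This is summed up by the limit of > 50000 nM in this assay, at which 2 of the 2 values shown sit.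

Compound 3, `Cc1cn(C2CC(N=[N+]=[N-])C(COC(=O)OCCCC(=O)O)O2)c(=O)[nH]c1=O`, has not yet been measured in this assay. It differs from compound 2 by carboxy in place of methyl on a saturated chain carbon, three bonds along the chain from an oxygen next to a carbonyl group. Among the measured compounds shown here, the only measured step, a step that the two limits leave unreadable from compound 1 to compound 2, concerns a different place and its size cannot be read, so nothing measured speaks for a step beyond the scatter. Compound 3 is therefore expected to remain at the same limit, with a step that the limit leaves unreadable from compound 2 to compound 3. The estimate for compound 3 in this assay is 80000 nM, ranging from 40000 nM to 200000 nM.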

Compound 3, half-maximal cytotoxic concentration: > 50000 nM
Compound 3: a limit, no number (the forecaster's own chance of this, stated with the estimate: 85%); the middle value lies beyond the limit too.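

In this assay, among the compounds shown here, compound 3 gives > 50000 nM as a limit of the assay and not a number, so no step among compound 1, compound 2 and compound 3 can be read. All three share one result: the limit of > 50000 nM in this assay, at which 3 of the 3 values shown sit. What remains open is the concentration at which any of these compounds turns cytotoxic, and whether the exchanged groups make any difference to it.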